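A few compounds are considered here, and "the series" means these few. Any claim that something is new, unique, unknown or untested is made for them only; others in the source may bear on it.

Compound 1 `O=C(/C=C/c1cccc(/C=C/C(=O)c2ccccc2)c1)NO` — 12000 nM
Compound 3 `O=C(/C=C/c1ccc(/C=C/C(=O)c2ccccc2)cn1)NO` — 27000 nM
Compound 2 `CN1CCN(c2ccccc2C(=O)/C=C/c2ccc(/C=C/C(=O)NO)nc2)CC1` — 469000 nM

Three hydroxamic acids were measured in a physicochemical assay for solubility, at pH 7.4; a higher number here means a more soluble compound, a lower number a less soluble compound. Compound 1 `O=C(/C=C/c1cccc(/C=C/C(=O)c2ccccc2)c1)NO` gives the lowest of the three numbers, 12000 nM. Compound 3 `O=C(/C=C/c1ccc(/C=C/C(=O)c2ccccc2)cn1)NO` stands nearest to it, at 27000 nM, while compound 2 `CN1CCN(c2ccccc2C(=O)/C=C/c2ccc(/C=C/C(=O)NO)nc2)CC1` lies furthest away, at 469000 nM. The difference between the core of compound 1 and the core of compound 3 is not broken down here.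

Compounds 3 and 2 differ in one place: 4-methylpiperazin-1-yl in place of hydrogen on an aromatic carbon. That change produced a 17-fold higher number from compound 3 to compound 2 (1.24 log units; beyond the scatter).

Compound 4 `CN1CCN(c2ccccc2C(=O)/C=C/c2cccc(/C=C/C(=O)NO)c2)CC1` has not yet been measured in this assay. It is related to compound 1 by the same change: 4-methylpiperazin-1-yl in place of hydrogen on an aromatic carbon. Since the place of the change is described in the same words for both pairs, the two steps are the same change applied to two different cores. The expectation for compound 4 therefore rests on the step from compound 3 to compound 2, and the step from compound 1 to compound 4 is expected to be of a similar size, a 15-fold higher number from compound 1 to compound 4 (1.18 log units; beyond the scatter), beside the earlier one. It is worth noting that compound 1 starts from a lower number than compound 3, and whether the change carries over at full size onto the core of compound 1 is not known from these three compounds alone. On that basis the estimated value for compound 4 in this assay is 180000 nM, with a range expected from 50000 nM to 500000 nM.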

Compound 4, solubility: 177000 nM
Estimate against measurement, compound 4: 1.0-fold (0.01 log units) above; the measured number falls inside the stated range.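

In this assay, 4-methylpiperazin-1-yl in place of hydrogen on an aromatic carbon gave a 15-fold higher number from compound 1 to compound 4 (1.17 log units; beyond the scatter) on the core of compound 1, and the same change had given a 17-fold higher number from compound 3 to compound 2 (1.24 log units; beyond the scatter) on the core of compound 3, so the step carried from one core to the other at much the same size, even though the two starting compounds stand apart. This is a reading of two pairs only, with the group at a single place, on an aromatic carbon ortho to a large group, and it shows no rule for any further core, nor for any other group or place in the series. The agreement between the two steps describes their size and not their origin, and nothing shown here bears on what lies behind either step.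

As far as these compounds go, what stays open is whether a smaller or differently built amine, such as morpholin-4-yl or dimethylamino, would bring a step of similar size at the same place on these two cores. From the compounds shown here alone, it is also open whether a carboxylic acid, or 4-methylpiperazin-1-yl held on a longer chain, would carry across the two cores as closely as the group in compound 2 and compound 4 did.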